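Isopropyl for methyl on the bis-trifluoromethyl thiourea

A few compounds are considered here, and "the series" means these few. Any claim that something is new, unique, unknown or untested is made for them only; others in the source may bear on it.

Three thioureas sharing the core of compound 1 `C[C@H](NC(=S)Nc1cc(C(F)(F)F)cc(C(F)(F)F)c1)c1nc2ccccc2[nH]1` have been measured in a functional assay on DU-145 cells (Homo sapiens) for cytotoxicity, read by MTT assay; a higher number here means a weaker inhibitor, a lower number a stronger inhibitor. Compound 1 gives 154000 nM, the second highest of the three numbers. Compound 3 `C[C@H](NC(=S)NCc1ccccc1)c1nc2ccccc2[nH]1` gives 226000 nM, which sits within the scatter of compound 1 and so allows no ranking between the two. Compound 2 `CC(C)[C@@H](NC(=S)Nc1ccccc1)c1nc2ccccc2[nH]1` gives 34800 nM, a lower number than compound 1 by a margin beyond the scatter; compound 2 differs from compound 1 both at the saturated chain carbon and at the aryl end of the thiourea, so no single change accounts for that gap.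

Compound 4 `CC(C)[C@H](NC(=S)Nc1cc(C(F)(F)F)cc(C(F)(F)F)c1)c1nc2ccccc2[nH]1` keeps the aryl end of compound 1 and carries the change (isopropyl in place of methyl on a saturated chain carbon bound to an amide-type nitrogen and an aromatic carbon). For the measured compounds named here, no measured pair isolates this change. Going by the values given here, the only measured compound with isopropyl at that position, compound 2, shows the lowest number in this assay, but its aryl group also differs, so the expectation rests on thin ground.

The step from compound 1 to compound 4 is expected to be a modest decrease in the number, a 2.2-fold lower number from compound 1 to compound 4 (0.34 log units; beyond the scatter), likely beyond the scatter but not certainly so. Compound 4 is estimated at 70000 nM, with a range from 25000 nM to 200000 nM.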

Compound 4, half-maximal inhibitory concentration: 26100 nM
The estimate for compound 4 lay 2.7-fold (0.43 log units) above the measured number; measured number inside the range.
By their numbers in this assay, from the lowest: compounds 4 and 2 (each within the scatter of the next); then compounds 1 and 3 (each within the scatter of the next).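

Isopropyl in place of methyl on a saturated chain carbon bound to an amide-type nitrogen and an aromatic carbon gives, in this assay, a 5.9-fold lower number from compound 1 to compound 4 (0.77 log units; beyond the scatter), and this pair is the first reading of the change with the aryl end held constant. The position therefore responds to this change on its own, at least with the 3,5-bis(trifluoromethyl)phenyl end of the thiourea, whereas the gap between compound 1 and compound 2 could not be assigned to any single difference. No measurement on hand bears on why the number falls with isopropyl at this carbon.

On these data alone, this remains a single pair, so it is open whether the same change gives a step of similar size with an unsubstituted phenyl or benzyl end on the thiourea. As far as these compounds go, it is also open how the number moves when a tert-butyl, a cyclohexyl or a longer chain such as n-butyl stands at the same carbon, and so whether the trend from methyl to isopropyl continues beyond isopropyl.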